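The source may hold more compounds than are shown below. What is called first, only, known or untested is meant among the compounds shown, and "the series" means these compounds.

Working notes on the series. Among the measured compounds shown here, in an ADME assay (liver) for metabolic stability, with Liver microsome (Canis lupus familiaris) as the target, read by LC-MS, using microsomes, with a stated time of 30 min, tested at 4 uM (on this read-out higher numbers stand for a more stable compound and lower numbers for a less stable compound), compound 1 `Cc1nc(N2CCN(C)CC2)c2nc(-c3cccc(Cl)c3)n(C3CCOCC3)c2n1` gives 45% and compound 2 `Cc1nc(N2CCN(C)CC2)c2nc(-c3ccccc3C)n(C3CCOCC3)c2n1` gives 39%, so compound 2 stands level with its only neighbour within the scatter. Compound 3 `COc1ccc(-c2nc3c(N4CCN(C)CC4)nc(C)nc3n2C2CCOCC2)c(C)c1` carries methoxy in place of hydrogen on an aromatic carbon. In words, methoxy replaces hydrogen on an aromatic carbon, turning 2-methylphenyl into 4-methoxy-2-methylphenyl. For the measured compounds named here, only one measured step bears on this: a number 6 percentage points lower from compound 1 to compound 2 (within the scatter), with 2-methylphenyl in place of 3-chlorophenyl. That step changes the same phenyl group and is small, but it adds no methoxy, so the data give no direct read on this change and set no firm direction. In this assay, the expected change is therefore small, with a tentative lean downward and nothing beyond the scatter: the estimated step is a number 5 percentage points lower from compound 2 to compound 3 (within the scatter). Compound 3 is expected at 34%, with an estimated range of 18% to 50%.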

Compound 3, percent of the compound remaining: 41%
Compound 3: the middle estimate sits 7 percentage points below what was measured; low and high end bracket the measured number.
By their numbers in this assay, from the lowest: compounds 2, 3 and 1 (each within the scatter of the next).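

In this assay, methoxy in place of hydrogen, para to a large group on the 2-methylphenyl group, gives a number 2 percentage points higher from compound 2 to compound 3 (within the scatter) and so adds a direct read on this position: this added group leaves the number within the scatter. The second comparison, with 4-methoxy-2-methylphenyl in place of 3-chlorophenyl, gives a number 4 percentage points lower from compound 1 to compound 3 (within the scatter) and shows that the three aryl groups are not separated by this read-out. No supporting information bears on why the number holds here.

The compounds shown leave open whether an amine or a carboxylic acid at this same position would move the number beyond the scatter. They also leave open whether a longer chain, such as ethoxy or propoxy in place of methoxy, would do so.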